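The source may hold more compounds than are shown below. What is called first, only, known or untested is meant among the compounds shown, and "the series" means these compounds.

Measured compounds:
- compound 1 `Cc1cc(OCCCCCCC[N+]2(C)CCCC2)cc(-n2cc(C(=O)Nc3cc(F)cc(F)c3)c(=O)c3ccc(N(C)C)nc32)c1`: 35.4%
- compound 2 `Cc1ccc(-n2cc(C(=O)Nc3cc(F)cc(F)c3)c(=O)c3ccc(N(C)C)nc32)cc1OCCCCCCC[N+]1(C)CCCC1`: 55.9%
- compound 3 `Cc1cc(OCCCCCCC[N+]2(C)CCCCC2)cc(-n2cc(C(=O)Nc3cc(F)cc(F)c3)c(=O)c3ccc(N(C)C)nc32)c1`: 79.7%

All three numbers come from an assay on LX2 cells for inhibition of COL1A1 promoter (Homo sapiens), read by a luciferase reporter, with a stated time of 24 h, tested at 50 uM; on this read-out higher numbers stand for a stronger effect at the one concentration tested and lower numbers for a weaker effect. Compound 1 and compound 2 are built from the same atoms joined differently; the difference between the two cores is not broken down here. Taken as they stand, the value of compound 2 lies between the values of compound 1 and compound 3.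

Compound 3 differs from compound 1 in one place:
a group of 7 heavy atoms (6 carbon, 1 nitrogen; one six-membered non-aromatic ring with 1 hetero atom) in place of a group of 6 heavy atoms (5 carbon, 1 nitrogen; one five-membered non-aromatic ring with 1 hetero atom), on a saturated chain carbon, seven bonds along the chain from an oxygen on an aromatic ring
Within the data shown here, this change gave a number 44.3 percentage points higher from compound 1 to compound 3 (beyond the scatter), the only step with a measured pair in the set.

Compound 4 `Cc1ccc(-n2cc(C(=O)Nc3cc(F)cc(F)c3)c(=O)c3ccc(N(C)C)nc32)cc1OCCCCCCC[N+]1(C)CCCCC1` has not yet been run in this assay. It differs from compound 2 as follows:
a group of 7 heavy atoms (6 carbon, 1 nitrogen; one six-membered non-aromatic ring with 1 hetero atom) in place of a group of 6 heavy atoms (5 carbon, 1 nitrogen; one five-membered non-aromatic ring with 1 hetero atom), on a saturated chain carbon, seven bonds along the chain from an oxygen on an aromatic ring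
Among the measured compounds shown here, the place lines for the two changes agree word for word, so this is the same change as the one from compound 1 to compound 3, now made on the core of compound 2.

The expectation for compound 4 rests on that one precedent: the change raised the read-out from compound 1 to compound 3 by a number 44.3 percentage points higher from compound 1 to compound 3 (beyond the scatter), and the same move is expected to raise compound 2 as well. Since compound 2 already gives 55.9% and the read-out cannot exceed full inhibition, the step is expected to come out smaller than the earlier one, estimated at a number 28.1 percentage points higher from compound 2 to compound 4 (beyond the scatter). For the measured compounds named here, compound 4 is thus estimated at 84%, with a range from 66% to 97%, wide because the single precedent a number 44.3 percentage points higher from compound 1 to compound 3 (beyond the scatter) is all that carries it.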

Compound 4, a percentage reported as inhibition, at one concentration (the size of the read-out at that concentration, not a potency): 45.1%
Estimate against measurement, compound 4: 38.9 percentage points above, and the stated range ends above it.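

In this assay, the six-membered ring group in place of the five-membered ring group gave a number 10.8 percentage points lower from compound 2 to compound 4 (beyond the scatter), so the rise seen on the core of compound 1 did not carry over to the core of compound 2. The change therefore has no single effect in this series, and its direction depends on the core that carries it: the same change on two cores in this assay, a number 44.3 percentage points higher (beyond the scatter) from compound 1 to compound 3 and a number 10.8 percentage points lower (beyond the scatter) from compound 2 to compound 4, 55.1 percentage points apart, beyond the scatter of two such steps

Among these compounds, this does not show which difference between the two cores matters, since compound 1 and compound 2 are built from the same atoms joined differently and only one pair per core is available; nor does it show how the change would behave on any third core, or at any other concentration, as each number is the size of the read-out at a single concentration and not a potency.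

Open, as far as these compounds go, is whether other groups in the same place, such as a morpholine ring, a seven-membered azepane ring or an open-chain trimethylammonium group, would also split between the two cores or behave alike on both. Also open, from the compounds shown here alone, is whether a shorter or longer chain would keep, shrink or reverse the difference between the two steps.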